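Swapping the amide for a urea: expected cytotoxicity

The compounds below may be only part of what the source reports. "The series", "measured", "known", "first", "only" and "open" are said of these compounds alone.

Compound 1: `COC(=O)c1ccc2c(ccn2-c2cccc(NC(=O)Nc3ccc(Cl)c(C(F)(F)F)c3)c2)n1`, > 10000 nM
Compound 2: `O=C(Nc1ccc(-n2ccc3nc(C(=O)NCc4ccccc4)ccc32)cc1)c1ccc(Cl)c(C(F)(F)F)c1`, 1500 nM

Both were tested in an ADME assay on HS27 cells (Homo sapiens) for cytotoxicity, read by MTT assay; a lower number here means a stronger inhibitor, a higher number a weaker inhibitor. For compound 1 the result is a limit of the assay and not a number, > 10000 nM; compound 1 sits at the limit of > 10000 nM in this assay, at which 1 of the 2 values shown sits. Within the data shown here, compound 2 is the only compound with a number, giving 1500 nM in this assay. Compound 3, `O=C(Nc1ccc(-n2ccc3nc(C(=O)NCc4ccccc4)ccc32)cc1)Nc1cccc(C(F)(F)F)c1`, is not yet measured. It differs from compound 2 by (3-(trifluoromethyl)phenyl)amino in place of 4-chloro-3-(trifluoromethyl)phenyl on a carbonyl carbon. Among the measured compounds shown here, no step between measured compounds is available, so the expectation rests on the two values alone. A modest weakening is expected, with the step in this assay estimated at a 2.3-fold higher number from compound 2 to compound 3 (0.37 log units; beyond the scatter). Compound 3 is expected to come out at 3500 nM, between 1000 nM and 10000 nM.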

Compound 3, half-maximal inhibitory concentration: > 10000 nM
Compound 3: no number, only a limit; the forecaster's own chance of this, stated with the estimate: 35%; middle value at least 2.8-fold (0.45 log units) away from the limit.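

In this assay, putting (3-(trifluoromethyl)phenyl)amino in place of 4-chloro-3-(trifluoromethyl)phenyl on the carbonyl carbon gives an at least 6.6-fold higher number from compound 2 to compound 3 (0.82 log units; beyond the scatter), so this position clearly matters for the read-out. The result for compound 3 is a limit of the assay, which leaves the full size of the step unknown, and most of the series now stands at that limit: the limit of > 10000 nM in this assay, at which 2 of the 3 values shown sit.

This change swaps the chlorine and adds the amino nitrogen together, so the two contributions cannot be separated. From the compounds shown here alone, how a fluorine or a methyl group in place of the chlorine would read also remains open.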